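The compounds below may be only part of what the source reports. "The series", "measured", "known", "first", "only" and "open" are said of these compounds alone.

Three measured compounds share one core and differ in the group attached to the amine nitrogen of the ring at the far end. Compound 1 `COC(=O)C1=C(C)N=C(C)/C(=C(/O)OC)C1c1cccc(N/C(=N/CCNC2CCN(c3ccccc3)CC2)NC#N)c1` gives 10 nM in an assay on SK-N-MC cells for inhibition of Neuropeptide Y receptor type 1 (Homo sapiens); on this read-out higher numbers stand for weaker inhibition and lower numbers for stronger inhibition. Compound 2 `COC(=O)C1=C(C)N=C(C)/C(=C(/O)OC)C1c1cccc(N/C(=N/CCNC2CCN(c3ccccc3C(F)(F)F)CC2)NC#N)c1` carries a trifluoromethyl group there and gives 14 nM; the step from compound 1 to compound 2 is a 1.4-fold higher number from compound 1 to compound 2 (0.15 log units; within the scatter), so the two show no real difference. Compound 3 `COC(=O)C1=C(C)N=C(C)/C(=C(/O)OC)C1c1cccc(NC(=O)NCCNC2CCN(c3ccccc3C#N)CC2)c1` gives 3 nM, the strongest inhibition of the three, since its distances to compound 1 and compound 2 both lie beyond the scatter.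

Compound 4 `COC(=O)C1=C(C)N=C(C)/C(=C(/O)OC)C1c1cccc(NC(=O)NCCNC2CCN(c3cccc(Cl)c3)CC2)c1` is not yet measured. The change from compound 3 is 3-chlorophenyl in place of 2-cyanophenyl on an amine nitrogen in a ring. Among the compounds with values here, the only measured step that bears on it is the exchange of one aromatic substituent for another on this same ring, from compound 1 to compound 2, which stayed within the scatter. Since that exchange left the number essentially unchanged, compound 4 is expected to sit close to compound 3, with a step of a 1.7-fold higher number from compound 3 to compound 4 (0.22 log units; within the scatter) at most. The estimate for compound 4 is therefore 5 nM, expected between 1.5 nM and 15 nM.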

Compound 4, half-maximal inhibitory concentration: 8 nM
Compound 4: the middle estimate sits 1.6-fold (0.20 log units) below what was measured; the range from low to high includes it.
By their numbers in this assay, from the lowest: compound 3; then compounds 4, 1 and 2 (each within the scatter of the next).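

In this assay, putting 3-chlorophenyl in place of 2-cyanophenyl on the amine nitrogen in the ring gives a 2.7-fold higher number from compound 3 to compound 4 (0.43 log units; beyond the scatter), whereas the earlier exchange on this aromatic ring gave only a 1.4-fold higher number from compound 1 to compound 2 (0.15 log units; within the scatter). The group on this nitrogen can therefore shift the number by more than the scatter, though this step is modest and compound 4 still gives 8 nM. No measurement on hand explains why the two groups differ.

The swap changes both the substituent, nitrile to chlorine, and its numbered place on the phenyl ring, so these compounds cannot show which of the two matters; 2-chlorophenyl and 3-cyanophenyl on the same core would separate them. From the compounds shown here alone, how a methoxy group or an amine on this phenyl ring would compare also remains open.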